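The source may report more compounds than this note shows. Statements on the series, on what has been measured and on what is new or still open speak of the compounds shown alone.

Compound 3 `Cc1ccccc1C(=O)Nc1ccc(S(=O)(=O)NC2CCN(C(N)=O)CC2)c2ccccc12` gives 243 nM in an assay on L1.2 cells for binding affinity to C-C chemokine receptor type 8 (Homo sapiens) (on this read-out lower numbers stand for stronger inhibition and higher numbers for weaker inhibition), the highest of the three numbers measured. Its nearest neighbour, compound 1 `CC(=O)N1CCC(NS(=O)(=O)c2ccc(NC(=O)c3ccccc3C)c3ccccc23)CC1`, gives 6.7 nM in this assay, and compound 2 `Cc1ccccc1C(=O)Nc1ccc(S(=O)(=O)NC2CCN(C(=O)C3CNC3)CC2)c2ccccc12` gives 1.5 nM. Among the compounds with values here, two measured steps bear on the change to compound 4 `CCN(CC)CCCC(=O)N1CCC(NS(=O)(=O)c2ccc(NC(=O)c3ccccc3C)c3ccccc23)CC1`, and both lead into compound 3: a 36-fold higher number from compound 1 to compound 3 (1.56 log units; beyond the scatter) and a 160-fold higher number from compound 2 to compound 3 (2.21 log units; beyond the scatter). Together they show that an amino group on this carbonyl carbon is met with a far higher number than either a methyl or an azetidin-3-yl, and the step of a 4.5-fold lower number from compound 1 to compound 2 (0.65 log units; beyond the scatter) adds that azetidin-3-yl does better than methyl. Compound 4 differs from compound 3 by 3-(diethylamino)propyl in place of amino on a carbonyl carbon; the amino group leaves and a carbon chain with one nitrogen enters in its place. On these grounds a large fall in the number is expected for compound 4 in this assay, as an 81-fold lower number from compound 3 to compound 4 (1.91 log units; beyond the scatter). The estimate for compound 4 is 3 nM, within a range of 1 nM to 15 nM.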

Compound 4, inhibition constant: 567 nM
For compound 4 the middle estimate is 190-fold (2.28 log units) below the measured one; measured number outside the range, above it.
By their numbers in this assay, from the lowest: compound 2; then compound 1; then compound 3; then compound 4.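

In this assay, 3-(diethylamino)propyl on this carbonyl carbon does not bring the number down from that of the amino compound, but raises it further: a 2.3-fold higher number from compound 3 to compound 4 (0.37 log units; beyond the scatter). Compound 4 also stands far from the methyl and azetidin-3-yl compounds, with an 85-fold higher number from compound 1 to compound 4 (1.93 log units; beyond the scatter) and a 380-fold higher number from compound 2 to compound 4 (2.58 log units; beyond the scatter), so a carbon-linked group in place of amino does not by itself give a low number at this position. Although azetidin-3-yl and 3-(diethylamino)propyl each carry a nitrogen, the evidence at hand offers no explanation for their gap.

The compounds shown leave open whether the rise follows the length of the chain or its diethylamino end. A shorter chain ending in dimethylamino, or a propyl chain ending in a hydroxyl group, would help separate the two.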